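Methyl to Trifluoromethyl Swap: Working Notes on Compounds 1 to 4

A few compounds are considered here, and "the series" means these few. Any claim that something is new, unique, unknown or untested is made for them only; others in the source may bear on it.

Measured in a functional assay on KBVIN cells (Homo sapiens) for antiproliferative activity, read by sulforhodamine B assay, with a stated time of 3 days; on this read-out higher numbers stand for an effect only at larger amounts of compound and lower numbers for an effect already at smaller amounts:
compound 1 `CCC1=C(O)c2c(oc(-c3ccc(C)cc3)cc2=O)C(CC)(CC)C1=O` gives 0.08 uM
compound 2 `CCC1=C(O)c2c(oc(-c3ccc(C(F)(F)F)cc3)cc2=O)C(CC)(CC)C1=O` gives 10.4 uM
compound 3 `CCC1=C(O)c2c(oc(-c3ccccc3C)cc2=O)C(CC)(CC)C1=O` gives 2.41 uM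

Compound 2 arises from compound 1 by trifluoromethyl in place of methyl on an aromatic carbon; the step is a 130-fold higher number from compound 1 to compound 2 (2.11 log units; beyond the scatter). Compound 3 differs from compound 1 by 2-methylphenyl in place of 4-methylphenyl on an aromatic carbon, and the step is a 30-fold higher number from compound 1 to compound 3 (1.48 log units; beyond the scatter). Compound 4 `CCC1=C(O)c2c(oc(-c3ccccc3C(F)(F)F)cc2=O)C(CC)(CC)C1=O` is not yet measured; it arises from compound 3 by trifluoromethyl in place of methyl on an aromatic carbon. This is the same kind of change as from compound 1 to compound 2, not the same: there the entering group sits para to a large group, here ortho to a large group. The change has been measured only once, so the expectation rests on that single step. Compound 4 is expected to move in the same direction, with an estimated 17-fold higher number from compound 3 to compound 4 (1.22 log units; beyond the scatter), taken somewhat smaller than the measured step because a 130-fold higher number from compound 1 to compound 2 (2.11 log units; beyond the scatter) started from a far lower value. Compound 4 is estimated at 40 uM, expected between 8 uM and 150 uM.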

Compound 4, concentration for half-maximal effect: 43.1 uM
Compound 4: the middle estimate sits 1.1-fold (0.03 log units) below what was measured, within the range that was stated.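

In this assay, trifluoromethyl in place of methyl on the core of compound 3 gives an 18-fold higher number from compound 3 to compound 4 (1.25 log units; beyond the scatter), so the change again comes with a higher number. The direction carries across the two cores, but the size does not: the same change on two cores in this assay, a 130-fold higher number (2.11 log units; beyond the scatter) from compound 1 to compound 2 and an 18-fold higher number (1.25 log units; beyond the scatter) from compound 3 to compound 4, 7.3-fold (0.86 log units) apart, beyond the scatter of two such steps. Two steps do not show why the size differs, since the entering group's position differs along with the core, and they do not show that the direction would hold on any further core in the series.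

The compounds shown carry only methyl or trifluoromethyl on the aromatic ring. Going by these compounds, how a chlorine atom, a methoxy group or an amine would behave there remains open.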